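This account rests on a few compounds, and the source may have more. Where it says the series, first, only, none or still open, it means among the compounds named here.

Of the compounds shown here, three have been tested for their ability to slow the growth of cultured cells, in a functional assay on HeLa cells (Homo sapiens) for antiproliferative activity, read by sulforhodamine B assay, with a stated time of 72 h; on this read-out higher numbers stand for weaker inhibition and lower numbers for stronger inhibition. Compound 1 `COc1cccc(NC(=S)N/N=C/c2ccc3ccccc3n2)c1` gives 74500 nM, the highest number of the three, so it is the weakest inhibitor in this set. Compound 3 `NC(=S)N/N=C/c1nc2ccccc2s1` gives 5350 nM, and compound 2 `Cc1csc2sc(/C=N/NC(N)=S)c(C)c12` gives 1120 nM. Both of these lie beyond the usual scatter from compound 1, compound 3 being the nearer and compound 2 the further away. Those two compounds share little of their structure with compound 1 beyond the thiourea-linked chain, so they say nothing directly about how small changes on the aromatic ring of compound 1 play out.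

Compound 4 `COc1ccccc1NC(=S)N/N=C/c1ccc2ccccc2n1` has not yet been measured. It differs from compound 1 only in where the methoxy group sits on the phenyl ring: 2-methoxyphenyl in place of 3-methoxyphenyl on an amide-type nitrogen. Among the measured compounds shown here, no measured pair in this set shows what such a change does here, so the expectation rests on the change itself, which keeps the same atoms and simply rearranges them. The step from compound 1 to compound 4 is expected to be small, with no clear direction, and likely within the scatter, giving a 1.5-fold lower number from compound 1 to compound 4 (0.17 log units; within the scatter). On that basis compound 4 is estimated at 50000 nM, with a plausible range from 15000 nM to 150000 nM.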

Compound 4, half-maximal inhibitory concentration: > 100000 nM
Compound 4 ended at the assay's limit; the forecaster's own chance of this, stated with the estimate: 20%; at least 2.0-fold (0.30 log units) between middle value and limit.
By their numbers in this assay, from the lowest: compound 2; then compound 3; then compound 1. At a limit, above all of these: compound 4.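

Compound 4 gives > 100000 nM in this assay, and this is a limit of the assay, not a number: the limit of > 100000 nM in this assay, at which 1 of the 4 values shown sits. Moving the methoxy group, so that 2-methoxyphenyl replaces 3-methoxyphenyl on the amide-type nitrogen, gives an at least 1.3-fold higher number from compound 1 to compound 4 (0.12 log units; that floor lies within the scatter). Among the compounds shown here, this is the first reading of any change at this position, and it shows only that the swap brought no stronger inhibition, since the printed step is a floor that does not settle whether the true gap is small or large.

The compounds shown leave open whether any group on this phenyl ring can bring the number down, for instance a hydroxyl group, an amine or a carboxylic acid in place of the methoxy group. They also leave open what the unsubstituted phenyl ring would give, which would show whether the methoxy group in either placement helps or harms inhibition on the shared core.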